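A few compounds are considered here, and "the series" means these few. Any claim that something is new, unique, unknown or untested is made for them only; others in the source may bear on it.

Series notes. Compound 1 `C/C(=N\NC(=O)c1cccc(S(=O)(=O)N2CCOCC2)c1)c1ccccc1O` and compound 2 `O=C(N/N=C/c1ccco1)c1cccc(S(=O)(=O)N2CCOCC2)c1` share one core and differ only in the group on the carbon with a double bond to nitrogen. In a functional assay on ECa-109 cells for antiproliferative activity against ECa-109 cell line (Homo sapiens), read by MTT assay, with a stated time of 72 h (on this read-out higher numbers stand for weaker inhibition and lower numbers for stronger inhibition), compound 1 gives 5450 nM. For compound 2 the result in this assay is a limit, > 100000 nM, and not a number. This is the limit of > 100000 nM in this assay, at which 1 of the 2 values shown sits. Among the compounds with values here, compound 2 thus stands at the limit, and compound 1 holds the only numerical value so far. Compound 3 `CCOc1cccc(/C=N/NC(=O)c2cccc(S(=O)(=O)N3CCOCC3)c2)c1O` remains to be measured in this assay; it differs from compound 2 by 3-ethoxy-2-hydroxyphenyl in place of furan-2-yl on a carbon with a double bond to nitrogen. The group that enters carries a hydroxyphenyl motif of the kind found in compound 1. Since compound 1 gives 5450 nM, the step of an at least 11-fold lower number from compound 2 to compound 3 (1.04 log units; beyond the scatter) is expected to run toward stronger inhibition and beyond the scatter, though its exact size is uncertain. Compound 3 is expected at 9000 nM, within 2000 nM to 60000 nM.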

Compound 3, half-maximal inhibitory concentration: 16500 nM
Estimate against measurement, compound 3: 1.8-fold (0.26 log units) below, within the range that was stated.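

In this assay the group on the carbon with a double bond to nitrogen now has a readable step: 3-ethoxy-2-hydroxyphenyl in place of furan-2-yl gives an at least 6.0-fold lower number from compound 2 to compound 3 (0.78 log units; beyond the scatter), toward stronger inhibition. Within the data shown here, the earlier compounds offered no step at this position, so this is the first sign that activity responds to a change of group here. Compound 2 stands at a limit and not a number, so the step fixes only a minimum size: the limit of > 100000 nM in this assay, at which 1 of the 3 values shown sits.

The change swaps the ring and brings in the hydroxy and ethoxy groups together, so the compounds shown do not tell which part carries the step. Plain phenyl, 2-hydroxyphenyl without the ethoxy, or a propoxy group in place of the ethoxy would separate these parts.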